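The source may hold more compounds than are shown below. What is called first, only, known or untested is meant among the compounds shown, and "the series" means these compounds.

Measured compounds in a functional assay on A549 cells (Homo sapiens) for cytotoxicity, read by sulforhodamine B assay, with a stated time of 72 h; on this read-out lower numbers stand for stronger inhibition and higher numbers for weaker inhibition:
- compound 1 `Nc1sc(-c2ccccc2)c(-c2ccc(Cl)cc2)c1C(=O)N1CCCC1` gives 5800 nM
- compound 2 `Nc1sc(-c2ccccc2)c(-c2ccc(Cl)cc2)c1C(=O)NCc1ccccc1` gives 8510 nM
- compound 3 `Nc1sc(-c2ccc(Cl)cc2)c(-c2ccc(Cl)cc2)c1C(=O)NC1CCCCC1` gives 2410 nM

Compound 2 gives the highest of the three numbers in this assay. Its nearest neighbour is compound 1, and the change a 1.5-fold higher number from compound 1 to compound 2 (0.17 log units; within the scatter) is within the scatter. Going by the values given here, compound 3 stands furthest from it, yet no single-point step connects compound 2 and compound 3, so only their two values can be compared.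

Compound 4 `Nc1sc(-c2ccc(F)cc2)c(-c2ccc(Cl)cc2)c1C(=O)NCc1ccccc1` differs from compound 2 in one place: fluoro in place of hydrogen on an aromatic carbon, sitting para to a large group, so that the phenyl becomes a 4-fluorophenyl. Among the compounds with values here, none of the measured steps touches this position, and the only measured step, a 1.5-fold higher number from compound 1 to compound 2 (0.17 log units; within the scatter), concerns the amide end of the molecule. There is thus no direct basis for expecting a change beyond the scatter, though compound 3, which carries a halogen in the same place on its phenyl, gives 2410 nM.

Compound 4 is therefore expected to give about 6500 nM, within a range from 3000 nM to 14000 nM. The expected step of a 1.3-fold lower number from compound 2 to compound 4 (0.12 log units; within the scatter) is small and not beyond the scatter.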

Compound 4, half-maximal inhibitory concentration: 9950 nM
Estimate against measurement, compound 4: 1.5-fold (0.18 log units) below, within the range that was stated.
By their numbers in this assay, from the lowest: compound 3; then compounds 1, 2 and 4 (each within the scatter of the next).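

In this assay, going by these compounds alone, fluoro in place of hydrogen on an aromatic carbon, which turns the phenyl into a 4-fluorophenyl, gives a 1.2-fold higher number from compound 2 to compound 4 (0.07 log units; within the scatter) and so provides the first measured step at this position, apart from the earlier step at the amide end. With the benzyl amide held fixed, this read-out does not separate the phenyl from the 4-fluorophenyl, so this one change at this position leaves the number within the scatter. Nothing measured here offers an explanation for this result.

The compounds shown leave open whether a different group in this place, such as chloro, methoxy or an amine, would move the number beyond the scatter with the benzyl amide kept. A single fluoro step also cannot say whether the same change would give a similar result alongside another amide, such as the pyrrolidine amide.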